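Pyridine attachment point swapped on the core of compound 1

A few compounds are considered here, and "the series" means these few. Any claim that something is new, unique, unknown or untested is made for them only; others in the source may bear on it.

Of the compounds shown here, three have been measured in a functional assay on Hep 3B2 cells (Homo sapiens) for inhibition, read by sulforhodamine B assay, with a stated time of 72 h; on this read-out lower numbers stand for stronger inhibition and higher numbers for weaker inhibition. Compound 1 `C[C@H](Nc1ncnc2[nH]cnc12)c1nn(-c2ccncc2)c2cc(F)ccc12` gives 21400 nM, the highest of the three numbers. Compound 2 `C[C@H](Nc1nc(N)nc(N)c1C#N)c1nn(-c2cccc(S(C)(=O)=O)c2)c2cc(F)ccc12` gives 19700 nM, which sits within the scatter of compound 1. Compound 3 `C[C@H](Nc1nc(N)nc(N)c1C#N)c1nn(-c2cccc(S(C)(=O)=O)c2)c2cc(Cl)ccc12` gives 5110 nM, the lowest of the three. Among the measured compounds shown here, the only single-point step among the measured compounds is a 3.9-fold lower number from compound 2 to compound 3 (0.59 log units; beyond the scatter), a change on the fused ring system rather than on the pyridine.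

Compound 4 `C[C@H](Nc1ncnc2[nH]cnc12)c1nn(-c2ccccn2)c2cc(F)ccc12` differs from compound 1 in one place: pyridin-2-yl in place of pyridin-4-yl on an aromatic nitrogen. The pyridine ring stays, but its point of attachment to the core moves.

For the measured compounds named here, no measured step touches this change. The step from compound 2 to compound 3 concerns a halogen on the fused ring, so it says nothing about how the pyridine attachment point matters. With no guide in the data, the expectation for this assay is no step beyond the scatter in either direction, and the estimated step is a 1.0-fold lower number from compound 1 to compound 4 (0.01 log units; within the scatter). From the compounds shown here alone, compound 4 is therefore expected to give about 21000 nM, with a range from 7000 nM to 60000 nM; the range is wide because compound 1 itself, at 21400 nM, is weakly active and the change is untested.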

Compound 4, half-maximal inhibitory concentration: > 40000 nM
Compound 4 was reported as a limit; the forecaster's own chance of this, stated with the estimate: 25%; middle value at least 1.9-fold (0.27 log units) from the limit.
By their numbers in this assay, from the lowest: compound 3; then compounds 2 and 1 (each within the scatter of the next). At a limit, above all of these: compound 4.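

In this assay compound 4 is reported only as a limit, not as a number: the limit of > 40000 nM in this assay, at which 1 of the 4 values shown sits. Moving the point where the pyridine joins the shared core, with pyridin-2-yl in place of pyridin-4-yl on the aromatic nitrogen, gives an at least 1.8-fold higher number from compound 1 to compound 4 (0.27 log units; that floor lies within the scatter). The earlier compounds shown here offered no step at this position; here the atoms stay the same and only the way they are joined changes, and pyridin-2-yl brings no stronger inhibition than pyridin-4-yl, although a floor within the scatter does not by itself establish a real loss.

The compounds shown leave open how pyridin-3-yl, or a phenyl ring carrying an amine or a carboxylic acid, would behave at this position on the core of compound 1. Also open, from the compounds shown here alone, is whether the change of chloro in place of fluoro on an aromatic carbon, seen as a 3.9-fold lower number from compound 2 to compound 3 (0.59 log units; beyond the scatter), would carry over to the pyridine-bearing compounds.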